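The compounds below may be only part of what the source reports. "The series", "measured", "known", "first", "only" and "open" are said of these compounds alone.

Measured compounds in an ADME assay on HOS cells (Homo sapiens) for cytotoxicity; a lower number here means that less compound is tolerated, a higher number that more compound is tolerated:
compound 1, `CN(C)C1CCN(c2cccc3nc(CN(C)[C@H]4CCCc5cccnc54)cn23)CC1`, gives 3400 nM;
compound 2, `CN(Cc1cn2c(N3CCN4CCCC4C3)cccc2n1)[C@H]1CCCc2cccnc21`, gives 3900 nM;
compound 3, `CN1CCN(c2cccn3cc(CN(C)[C@H]4CCCc5cccnc54)nc23)CC1`, gives > 5000 nM, which is a limit of the assay and not a number.

Compound 2 stands at the highest of the two numbers that were obtained in this assay; its nearest neighbour is compound 1, and the step of a 1.1-fold higher number from compound 1 to compound 2 (0.06 log units; within the scatter) is within the scatter. The third value, that of compound 3, sits at the limit described by the limit of > 5000 nM in this assay, at which 1 of the 3 values shown sits.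

Compound 4, `CN1CCN(c2cccc3nc(CN(C)[C@H]4CCCc5cccnc54)cn23)CC1`, is still to be measured in this assay. It differs from compound 2 in one place: a group of 7 heavy atoms (5 carbon, 2 nitrogen; one six-membered non-aromatic ring with 2 hetero atoms) in place of a group of 9 heavy atoms (7 carbon, 2 nitrogen; one five-membered non-aromatic ring with 1 hetero atom, one six-membered non-aromatic ring with 2 hetero atoms), on an aromatic carbon

Among the measured compounds shown here, the only measured step that bears on this change is the exchange of the group on the same aromatic carbon between compound 1 and compound 2, and that step, a 1.1-fold higher number from compound 1 to compound 2 (0.06 log units; within the scatter), stayed within the scatter. Compound 3 carries the same 4-methylpiperazin-1-yl group as compound 4, though on a differently arranged core, and its value is a limit rather than a number. A step of no size beyond the scatter, or a somewhat higher number, is therefore expected from compound 2 to compound 4, a 1.2-fold higher number from compound 2 to compound 4 (0.06 log units; within the scatter). Compound 4 is estimated to give 4500 nM in this assay, within a range of 2500 nM to 9000 nM.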

Compound 4, half-maximal cytotoxic concentration: 4500 nM
Compound 4: middle estimate and measured number agree at the digits printed, within the range that was stated.
By their numbers in this assay, from the lowest: compounds 1, 2 and 4 (each within the scatter of the next). At a limit, above all of these: compound 3.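

In this assay, the aromatic carbon next to the ring nitrogen has now carried three different groups, and neither new step leaves the scatter: a 1.2-fold higher number from compound 2 to compound 4 (0.06 log units; within the scatter), and a 1.3-fold higher number from compound 1 to compound 4 (0.12 log units; within the scatter). The earlier step at this place exchanged two groups of equal heavy-atom count, so it could not show what a smaller group does; here the five-membered non-aromatic ring is lost with the change to 4-methylpiperazin-1-yl, and the number still cannot be told apart from that of compound 2. Among the compounds with a number, this position has therefore so far tolerated changes in both ring make-up and group size without a readable shift, while compound 3 stands at a limit and not at a number: the limit of > 5000 nM in this assay, at which 1 of the 4 values shown sits.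

All three groups at this position are non-aromatic nitrogen rings, so the compounds shown leave open whether a carboxylic acid, a morpholine ring or a simple open-chain amine on the same carbon would shift the number beyond the scatter. They also leave open how far compound 3 lies from the others, as it has no number that could be compared.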